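Following the step from compound 2 to compound 3

A few compounds are considered here, and "the series" means these few. Any claim that something is new, unique, unknown or untested is made for them only; others in the source may bear on it.

Measured so far in an ADME assay on MDCK cells (Canis lupus familiaris) for permeability, in the apical to basolateral direction; on this read-out higher numbers stand for higher permeability and lower numbers for lower permeability (permeability values):
compound 1 (`CC(C)[C@H](C[C@H]1OC(=O)NC1=O)c1ccc(-c2ccc3cccc(F)c3c2)[nH]c1=O`) gives 10.3 10^-6 cm/s 
compound 2 (`CC(C)[C@@H](c1ccc(-c2ccc3cccc(F)c3c2)[nH]c1=O)[C@H]1OC(=O)NC1=O`) gives 9.14 10^-6 cm/s 

Compound 2 (9.14 10^-6 cm/s) lies within the scatter of compound 1 (10.3 10^-6 cm/s), so the two numbers cannot be ranked. Compound 3 (`CC(C)[C@H](C[C@@H]1OC(=O)NC1=O)c1ccc(-c2ccc3cccc(F)c3c2)[nH]c1=O`), not yet measured, has (2,4-dioxo-1,3-oxazolidin-5-yl)methyl in place of 2,4-dioxo-1,3-oxazolidin-5-yl on a saturated chain carbon bound to an aromatic carbon and a saturated chain carbon. Among the measured compounds shown here, the only measured step that bears on this is the same exchange in the opposite direction (a 1.1-fold lower number from compound 1 to compound 2 (0.05 log units; within the scatter)), and it stayed within the scatter. One step is slender evidence, but on it no change beyond the scatter is expected in this assay. The estimated step is small (a 1.1-fold higher number from compound 2 to compound 3 (0.04 log units; within the scatter)). Compound 3 is estimated at 10 10^-6 cm/s (expected range 6 10^-6 cm/s to 16 10^-6 cm/s).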

Compound 3, apparent permeability: 10.8 10^-6 cm/s
Compound 3: middle estimate off by 1.1-fold (0.03 log units), on the low side; measured number inside the range.
By their numbers in this assay, from the lowest: compounds 2, 1 and 3 (each within the scatter of the next).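

In this assay, the exchange of 2,4-dioxo-1,3-oxazolidin-5-yl and (2,4-dioxo-1,3-oxazolidin-5-yl)methyl now has a direct reading in this direction, a 1.2-fold higher number from compound 2 to compound 3 (0.07 log units; within the scatter). New here is a change of configuration alone, at a stereocentre on a saturated ring carbon, which gives a 1.0-fold higher number from compound 1 to compound 3 (0.02 log units; within the scatter): the fact that compounds 1 and 3 differ only in the configuration as drawn. Across these three compounds, neither the exchange nor the change of configuration moves the read-out of this assay beyond the scatter.

From the compounds shown here alone, all three compounds carry the 2,4-dioxo-1,3-oxazolidin-5-yl group, so it remains open what an amine, a carboxylic acid or a longer chain at this place on a saturated chain carbon would give. Going by these compounds, it also remains open whether the same small steps would be seen on a core other than the one shared here.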